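A few compounds are considered here, and "the series" means these few. Any claim that something is new, unique, unknown or untested is made for them only; others in the source may bear on it.

Three compounds share one core and differ only in the methoxyphenyl group on a carbonyl carbon. In a functional assay on MCF7 cells (Homo sapiens) for inhibition, read by MTT assay, with a stated time of 24 h (a higher number here means a weaker inhibitor of growth, a lower number a stronger inhibitor of growth), compound 1 `COc1ccc2c(c1)c(-c1nc3ccccc3n1C(=O)c1ccccc1OC)cn2C` gives 23900 nM, compound 2 `COc1cccc(C(=O)n2c(-c3cn(C)c4ccc(OC)cc34)nc3ccccc32)c1` gives 14600 nM, and compound 3 `COc1ccc(C(=O)n2c(-c3cn(C)c4ccc(OC)cc34)nc3ccccc32)cc1` gives 14800 nM. Compound 3 therefore stands with the other two inside the usual scatter, and the three cannot be ranked.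

Compound 4 `COc1ccc2c(c1)c(-c1nc3ccccc3n1C(=O)c1ccccc1Br)cn2C` has not yet been measured. It differs from compound 3 by one swap, 2-bromophenyl in place of 4-methoxyphenyl on a carbonyl carbon. The measured steps that bear on this swap are a 1.6-fold lower number from compound 1 to compound 3 (0.21 log units; within the scatter), a 1.0-fold higher number from compound 2 to compound 3 (0.01 log units; within the scatter) and a 1.6-fold lower number from compound 1 to compound 2 (0.21 log units; within the scatter), all within the scatter. None of them brings in bromine, so they offer only a loose guide. Compound 1, the closest match by group name with its 2-methoxyphenyl, gives 23900 nM.

In this assay the expected step is a 1.2-fold higher number from compound 3 to compound 4 (0.09 log units; within the scatter), towards a slightly higher number but not beyond the scatter. The estimated value for compound 4 is 18000 nM, with an expected range of 8000 nM to 40000 nM.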

Compound 4, concentration for 50% growth inhibition: 55800 nM
Beside the measured number, compound 4's estimate is 3.1-fold (0.49 log units) below it; measured number outside the range, above it.
By their numbers in this assay, from the lowest: compounds 2, 3 and 1 (each within the scatter of the next); then compound 4.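

Among the groups on the carbonyl carbon, the three methoxyphenyl groups could not be told apart, but 2-bromophenyl gives the first change beyond the scatter in this assay: a 3.8-fold higher number from compound 3 to compound 4 (0.58 log units; beyond the scatter) and a 3.8-fold higher number from compound 2 to compound 4 (0.58 log units; beyond the scatter). The tightest comparison is bromo in place of methoxy on an aromatic carbon, with a 2.3-fold higher number from compound 1 to compound 4 (0.37 log units; beyond the scatter); this is also beyond the scatter, so the group itself matters here and not only which methoxyphenyl is compared, and the higher number means a weaker inhibitor of growth. Nothing measured here accounts for this loss.

With only one bromo compound shown, it remains open whether this step is particular to bromo. An amine or a carboxylic acid in the same place could show whether other groups shift the number in the same direction.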